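Methylsulfonyl for Cyclopropylcarbonyl on the Aniline Nitrogen

This account rests on a few compounds, and the source may have more. Where it says the series, first, only, none or still open, it means among the compounds named here.

Measured compounds:
compound 1, `CC(C)(C)c1cc(NC(=O)Nc2ccc(Cl)cc2)n(-c2ccc(N)cc2)n1`: 2 degrees C
compound 2, `CC(C)(C)c1cc(NC(=O)Nc2ccc(Cl)cc2)n(-c2ccc(NC(=O)C3CC3)cc2)n1`: 3.4 degrees C

Within the data shown here, in an assay on isolated protein for inhibition of serine/threonine-protein kinase 10 (Homo sapiens), read by thermal shift assay, tested at 10 uM (on this read-out lower numbers stand for weaker stabilisation of the target and higher numbers for stronger stabilisation of the target against heat), compound 1 gives 2 degrees C, and compound 2 gives 3.4 degrees C. Compound 2 therefore stands highest of the two numbers; its only neighbour is compound 1, and the step of a number 1.4 degrees C higher from compound 1 to compound 2 (beyond the scatter) lies beyond the scatter. Compound 3, `CC(C)(C)c1cc(NC(=O)Nc2ccc(Cl)cc2)n(-c2ccc(NS(C)(=O)=O)cc2)n1`, has not yet been measured in this assay. It differs from compound 2 in one place: methylsulfonyl in place of cyclopropylcarbonyl on a nitrogen on an aromatic ring. Among the measured compounds shown here, only one measured step touches this position, a number 1.4 degrees C higher from compound 1 to compound 2 (beyond the scatter), which put the cyclopropylcarbonyl onto a nitrogen that had carried hydrogen and gave a modest rise. For the measured compounds named here, no measured pair compares two different groups on that nitrogen, so there is no direct guide for exchanging one for the other. Since both compound 2 and compound 3 carry a substituent on that nitrogen rather than hydrogen, the step is expected to be small, a number 0.40 degrees C lower from compound 2 to compound 3 (within the scatter), and may well fall within the scatter. Compound 3 is accordingly expected to give about 3 degrees C in this assay, in a range from 1.5 degrees C to 4.5 degrees C.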

Compound 3, shift of the target's melting temperature: 8.9 degrees C
Estimate against measurement, compound 3: 5.9 degrees C below; measured number above the stated range.
By their numbers in this assay, from the lowest: compound 1; then compound 2; then compound 3.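

In this assay, the nitrogen on the aromatic ring proves sensitive not only to whether it carries a substituent but also to which one, since exchanging cyclopropylcarbonyl for methylsulfonyl gives a number 5.5 degrees C higher from compound 2 to compound 3 (beyond the scatter). Measured from the unsubstituted nitrogen, methylsulfonyl gives a number 6.9 degrees C higher from compound 1 to compound 3 (beyond the scatter), whereas cyclopropylcarbonyl gave only a number 1.4 degrees C higher from compound 1 to compound 2 (beyond the scatter), so among these three compounds, replacing the hydrogen does not by itself account for the size of the rise. Nothing available explains why these two groups differ so widely on this read-out.

The change replaces the carbonyl with a sulfonyl and the cyclopropyl ring with a methyl in a single step, so the compounds shown cannot apportion the rise between those two parts. Cyclopropylsulfonyl or acetyl on the same nitrogen would separate them, and an ethylsulfonyl group would show whether a longer chain on the sulfur keeps the higher number seen with compound 3.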